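A few compounds are considered here, and "the series" means these few. Any claim that something is new, unique, unknown or untested is made for them only; others in the source may bear on it.

- Compound 1 `C[C@@H]1CCN(c2cc(-c3ccccc3)nc3ncnn23)C[C@@H]1N(C)c1ncnc2[nH]ccc12` gives > 100000 nM (a limit)
- Compound 2 `Cc1cc(N2CC[C@@H](C)[C@@H](N(C)c3ncnc4[nH]ccc34)C2)n2nc(SCc3csc4ccc(Cl)cc34)nc2n1` gives > 100000 nM (a limit)
- Compound 3 `CCCCCc1c(C)nc2nc(SCc3ccc(Cl)cc3)nn2c1N1CC[C@@H](C)[C@@H](N(C)c2ncnc3[nH]ccc23)C1` gives > 100000 nM (a limit)

In a toxicity assay on GES1 cells (Homo sapiens) for inhibition, read by MTT assay, with a stated time of 72 h (on this read-out higher numbers stand for weaker inhibition and lower numbers for stronger inhibition), compound 2 gives only a limit and not a number, and the other two compounds share that position: the limit of > 100000 nM in this assay, at which 3 of the 3 values shown sit, is where all of them stand. Compound 4 `Cc1cc(N2CC[C@@H](C)[C@@H](N(C)c3ncnc4[nH]ccc34)C2)n2nc(SCc3ccc(F)c(Cl)c3)nc2n1` carries 3-chloro-4-fluorophenyl in place of 5-chloro-1-benzothiophen-3-yl on a saturated chain carbon bound to a sulfur, and 3-chloro-4-fluorophenyl in place of 5-chloro-1-benzothiophen-3-yl on a saturated chain carbon bound to a sulfur is the whole difference. For the measured compounds named here, no measured compound gives a number here to guide the expectation. The expected size of a number no higher from compound 2 to compound 4 (the limit leaves the size open) in this assay is none beyond the scatter, in neither direction. The estimate for compound 4 is 100000 nM with an expected range from 40000 nM to 200000 nM.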

Compound 4, half-maximal inhibitory concentration: > 100000 nM
Compound 4: no number, only a limit; the forecaster's own chance of this, stated with the estimate: 80%; the middle value lies on the limit itself.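

Compound 4 gives > 100000 nM in this assay, a limit and not a number. Compound 2 also gives only a limit, so the step between compound 2 and compound 4 cannot be read. The compounds shown leave open whether 3-chloro-4-fluorophenyl in place of 5-chloro-1-benzothiophen-3-yl changes the inhibition at all.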